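Ethoxyphenyl in place of methylphenyl on the amide nitrogen

The source may hold more compounds than are shown below. What is called first, only, known or untested is meant among the compounds shown, and "the series" means these compounds.

Compound 1, `Cc1cccc(NC(=O)c2cccc(/C=C3\CC(=O)N(c4ccccc4)C3=O)c2)c1`, sits at the edge of what the measurement can report. In an ADME assay on HCT-116 cells (Homo sapiens) for cytotoxicity, read by MTT assay, with a stated time of 72 h (a lower number here means a stronger inhibitor, a higher number a weaker inhibitor), compound 1 gives > 100000 nM, which is a limit of the assay and not a number. Compound 2, `CCCCCN1C(=O)C/C(=C\c2cccc(C(=O)Nc3cccc(F)c3)c2)C1=O`, belongs to the same series and carries a different group on the same amide nitrogen. In this assay compound 2 also returns only a limit, > 100000 nM. Within the data shown here, the whole of the evidence so far is the limit of > 100000 nM in this assay, at which 2 of the 2 values shown sit; no pair of measured compounds differs in one place, and no step size has been measured anywhere in the set. Compound 3, `CCOc1ccc(NC(=O)c2cccc(/C=C3\CC(=O)N(c4ccccc4)C3=O)c2)cc1`, awaits measurement. It differs from compound 1 by a single change: 4-ethoxyphenyl in place of 3-methylphenyl on an amide-type nitrogen. Among the measured compounds shown here, no measured step supports a shift in either direction for such a change, and none beyond the scatter is expected. The expected step is a number no higher from compound 1 to compound 3 (the limit leaves the size open). Compound 3 is therefore estimated at 100000 nM, between 30000 nM and 300000 nM, and is expected most likely to be reported as a limit once more.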

Compound 3, half-maximal inhibitory concentration: 84800 nM
Compound 3: the middle estimate sits 1.2-fold (0.07 log units) above what was measured; low and high end bracket the measured number.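

Among these compounds, with 4-ethoxyphenyl on the amide nitrogen, compound 3 gives 84800 nM in this assay, the first reading in the set that is a number and not a limit of the assay. The change from 3-methylphenyl to 4-ethoxyphenyl comes out as an at least 1.1-fold lower number from compound 1 to compound 3 (0.07 log units; that floor lies within the scatter); this is a floor only, and the true size of the change cannot be read from it, so the result does not show whether this place on the series responds to such a change at all. What compound 3 adds is a numeric anchor for later comparisons on this amide nitrogen, while most of the set still stays at the edge of what the read-out reports: the limit of > 100000 nM in this assay, at which 2 of the 3 values shown sit.

The compounds shown leave open whether the ring oxygen of the ethoxy group, the 4-placement named in 4-ethoxyphenyl, or the extra heavy atoms carry any part of this reading, since the single change alters all of them at once. They also leave open whether a longer chain such as butoxy, an amine or a carboxylic acid on this phenyl ring would move the number beyond the scatter.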